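Two Aryl Ureas Measured, a Third Awaits Its Number

The source may hold more compounds than are shown below. What is called first, only, known or untested is meant among the compounds shown, and "the series" means these compounds.

Measured compounds:
compound 1 `Cc1ccc(Nc2cc(NC(=O)Nc3c(Cl)cccc3Cl)ncn2)cc1F` — 92%
compound 2 `COc1ccc(Nc2cc(NC(=O)Nc3c(Cl)cccc3Cl)ncn2)cc1C` — 80.1%

Compound 1 and compound 2 share a core and differ only in the group on a nitrogen on an aromatic ring. In a functional assay on PC-9 cells (Homo sapiens) for inhibition, read by MTT assay, with a stated time of 48 h, tested at 10 uM (a lower number here means less inhibition, a higher number more inhibition at the concentration tested (going by the name of the read-out)), compound 1 gives 92%, while compound 2 gives 80.1%. Among the measured compounds shown here, the one recorded step, a number 11.9 percentage points lower from compound 1 to compound 2 (beyond the scatter), puts compound 2 at the lower of the two numbers, with compound 1 the nearer and only neighbour.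

Compound 3 `O=C(Nc1cc(Nc2ccc(F)c(Cl)c2)ncn1)Nc1c(Cl)cccc1Cl` has not yet been measured. It differs from compound 2 by 3-chloro-4-fluorophenyl in place of 4-methoxy-3-methylphenyl on a nitrogen on an aromatic ring. For the measured compounds named here, the only step that bears on this change is the one from compound 1 to compound 2, modest in size and beyond the scatter; there compound 1, with its 3-fluoro-4-methylphenyl, gave the higher number. Compound 3 carries a 3-chloro-4-fluorophenyl, and on that single precedent a rise back toward the level of compound 1 is expected, though the evidence is thin. The expected step is a number 7.9 percentage points higher from compound 2 to compound 3 (within the scatter). For compound 3 the estimated value in this assay is 88%, with a range from 74% to 97%.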

Compound 3, a percentage reported as inhibition, at one concentration (the size of the read-out at that concentration, not a potency): 91.1%
Estimate against measurement, compound 3: 3.1 percentage points below; low and high end bracket the measured number.
By their numbers in this assay, from the lowest: compound 2; then compounds 3 and 1 (each within the scatter of the next).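

In this assay, a second replacement of 4-methoxy-3-methylphenyl on a nitrogen on an aromatic ring gives a change beyond the scatter, a number 11 percentage points higher from compound 2 to compound 3 (beyond the scatter), so compound 2 now stands lowest of the three against two different groups rather than one. The two replacing groups cannot be told apart at this concentration, with a number 0.9 percentage points lower from compound 1 to compound 3 (within the scatter), which means that 3-fluoro-4-methylphenyl and 3-chloro-4-fluorophenyl, though they differ in their substituents, give numbers at one level within the scatter. No measurement here accounts for the gap between these groups and 4-methoxy-3-methylphenyl.

As far as these compounds go, it remains open whether that level would hold if an amine or a carboxylic acid were carried on the phenyl ring at this nitrogen, or if a longer chain stood there in place of the ring. The rest of the shared core is the same in all three compounds, so nothing shown tells whether the differences among these groups would persist with any other part of the structure changed.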